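A few compounds are considered here, and "the series" means these few. Any claim that something is new, unique, unknown or untested is made for them only; others in the source may bear on it.

Measured compounds:
compound 1 `CCOC(=O)c1c(N)sc(/N=C/c2ccncc2)c1C(=O)OCC`: 119000 nM
compound 2 `CCOC(=O)c1c(N)sc(/N=C/c2ccc([N+](=O)[O-])cc2)c1C(=O)OCC`: 141000 nM

In a functional assay on Ishikawa cells (Homo sapiens) for inhibition, read by MTT assay, with a stated time of 48 h (on this read-out higher numbers stand for weaker inhibition and lower numbers for stronger inhibition), compound 1 gives 119000 nM, the smaller of the two numbers shown, and compound 2 gives 141000 nM; the gap, a 1.2-fold higher number from compound 1 to compound 2 (0.07 log units; within the scatter), lies within the scatter. Compound 3 `CCOC(=O)c1c(N)sc(/N=C/c2ccc(F)cc2)c1C(=O)OCC` has not been measured. It differs from compound 1 by 4-fluorophenyl in place of pyridin-4-yl on a carbon with a double bond to nitrogen. For the measured compounds named here, only the step from compound 1 to compound 2 bears on such a swap on the carbon with a double bond to nitrogen, and it stayed within the scatter, so no step beyond the scatter is expected in this assay, that is a 1.1-fold higher number from compound 1 to compound 3 (0.04 log units; within the scatter). Compound 3 is therefore estimated at 130000 nM, within a range from 60000 nM to 280000 nM.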

Compound 3, half-maximal inhibitory concentration: 32100 nM
Compound 3: middle estimate off by 4.0-fold (0.61 log units), on the high side; the whole stated range lies above it.
By their numbers in this assay, from the lowest: compound 3; then compounds 1 and 2 (each within the scatter of the next).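

In this assay the group on the carbon with a double bond to nitrogen does matter: the change gives a 3.7-fold lower number from compound 1 to compound 3 (0.57 log units; beyond the scatter) and fluoro in place of nitro on an aromatic carbon gives a 4.4-fold lower number from compound 2 to compound 3 (0.64 log units; beyond the scatter). The earlier pair, pyridin-4-yl and 4-nitrophenyl, had shown no step beyond the scatter, so compound 3 is the first to separate from the others at this position. Nothing measured here accounts for this difference. Going by these compounds, whether a chloro or a methoxy group on the aromatic carbon that carries fluoro in compound 3 would give a similar number stays open, as does the number for a plain phenyl at this place.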